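The source may hold more compounds than are shown below. What is called first, only, known or untested is meant among the compounds shown, and "the series" means these compounds.

Measured so far:

Compound 1 `Cc1ccc(S(=O)(=O)N[C@@H](CC(=O)NC(C)(C)C)C(=O)NCCNC(=O)c2c(O)cccc2F)cc1` — > 11000 nM
Compound 2 `Cc1ccc(S(=O)(=O)N[C@@H](CC(=O)NC(C)(C)C)C(=O)NCCNC(=O)NCc2ccccc2)cc1` — > 11000 nM

In an ADME assay on HepG2 cells (Homo sapiens) for cytotoxicity (a lower number here means that less compound is needed, a higher number that more compound is needed for the effect), compound 1 gives > 11000 nM, which is a limit of the assay and not a number. Compound 2 gives > 11000 nM, likewise a limit. Among the measured compounds shown here, the one measured step, a step that the two limits leave unreadable from compound 1 to compound 2, is therefore unreadable in size and direction. Both values sit at the limit of > 11000 nM in this assay, at which 2 of the 2 values shown sit, so compound 1 stands at the limit itself, with no number to place it more finely.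

Compound 3 `Cc1ccc(S(=O)(=O)N[C@@H](CC(=O)NC(C)(C)C)C(=O)NCCNS(=O)(=O)c2ccccc2)cc1` differs from compound 1 by a group of 9 heavy atoms (6 carbon, 2 oxygen, 1 sulfur; one six-membered aromatic ring of carbon only) in place of a group of 10 heavy atoms (7 carbon, 2 oxygen, 1 fluorine; one six-membered aromatic ring of carbon only), on an amine nitrogen. For the measured compounds named here, no measured step bears directly on this change, and the only step available, from compound 1 to compound 2, is unreadable between its two limits. Nothing in these numbers therefore points to a step beyond the scatter in either direction. Compound 3 is expected to give 11000 nM, with a range of 5000 nM to 30000 nM. The expected step is a number no higher from compound 1 to compound 3 (the limit leaves the size open), most likely again reported only as a limit.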

Compound 3, half-maximal effective concentration: > 11000 nM
Compound 3 gave a limit, no number; the forecaster's own chance of this, stated with the estimate: 80%; the middle value sits exactly at the limit.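

In this assay compound 3 gives > 11000 nM, a limit of the assay and not a number. The steps from compound 1 and compound 2 to compound 3 therefore cannot be read: the limit of > 11000 nM in this assay, at which 3 of the 3 values shown sit.

The compounds shown leave open whether the groups on the amine nitrogen differ at all in this assay.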